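The source may hold more compounds than are shown below. What is called first, only, known or untested is meant among the compounds shown, and "the series" means these compounds.

Compound 1 `COC(=O)[C@@]1(C)C[C@@H](c2coc3ccc(Br)cc3c2=O)N(c2ccccc2)O1`: 14700 nM
Compound 2 `O=C1[C@H]2[C@H](ON(c3ccccc3)[C@@H]2c2coc3ccc(F)cc3c2=O)C(=O)N1c1ccccc1`: 43500 nM
Compound 3 `O=c1c([C@@H]2C[C@H](c3ccccc3)ON2c2ccccc2)coc2ccc(Br)cc12`: 60000 nM

In a functional assay on THP-1 cells (Homo sapiens) for inhibition, read by sulforhodamine B assay, with a stated time of 48 h (on this read-out lower numbers stand for stronger inhibition and higher numbers for weaker inhibition), compound 3 gives 60000 nM. Among the measured compounds shown here, that number lies within the scatter of the one for compound 2, and beyond the scatter above the one for compound 1. Compound 4 `Cc1ccc2occ([C@@H]3C[C@H](c4ccccc4)ON3c3ccccc3)c(=O)c2c1` keeps the core of compound 3 and carries methyl in place of bromo on an aromatic carbon. For the measured compounds named here, no measured pair shows this change on its own, so the data offer no direct guide. The expectation in this assay is therefore no step beyond the scatter, in either direction. The estimate amounts to an expected step of a 1.2-fold lower number from compound 3 to compound 4 (0.08 log units; within the scatter). For compound 4 the estimated value is 50000 nM, with an expected range of 20000 nM to 120000 nM.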

Compound 4, half-maximal inhibitory concentration: > 60000 nM
Compound 4 ended at the assay's limit; the forecaster's own chance of this, stated with the estimate: 15%; at least 1.2-fold (0.07 log units) between middle value and limit.
By their numbers in this assay, from the lowest: compound 1; then compounds 2 and 3 (each within the scatter of the next).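

In this assay compound 4 gives > 60000 nM, which is a limit of the assay and not a number. Methyl in place of bromo on this aromatic carbon is the first change in the series seen on its own, and it gives a number no lower from compound 3 to compound 4 (the limit leaves the size open) here. The size of this step cannot be read because the value stops at a limit: the limit of > 60000 nM in this assay, at which 1 of the 4 values shown sits.

Whether the bromo position matters at all in this series therefore stays unresolved. From the compounds shown here alone, it also remains open whether an amine or a carboxylic acid on this aromatic carbon would give a readable number, lower than that of compound 3.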